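This account rests on a few compounds, and the source may have more. Where it says the series, first, only, none or still open, it means among the compounds named here.

Within the data shown here, compound 1, with the structure `COc1ccc(-c2ncnn2-c2cc(OC)c(OC)c(OC)c2)cc1`, is the only member of this small set to return a numerical result: in a functional assay on HeLa cells (Homo sapiens) for antiproliferative activity, read by MTT assay, with a stated time of 72 h (a higher number here means a weaker inhibitor, a lower number a stronger inhibitor), compound 1 gives 280 nM. Compound 2, with the structure `COc1cc(-c2ncnn2-c2ccc(Cl)c(Cl)c2)cc(OC)c1OC`, reaches only a limit of the assay in this assay, reported as > 10000 nM. Among the measured compounds shown here, compound 1 therefore stands alone as the one measured number, the other result being (the limit of > 10000 nM in this assay, at which 1 of the 2 values shown sits).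

Compound 3, with the structure `COc1cc(-n2ncnc2-c2ccc(SC)cc2)cc(OC)c1OC`, differs from compound 1 in a single spot: methylsulfanyl in place of methoxy on an aromatic carbon. For the measured compounds named here, no pair of measured compounds differs in just one place, so the size of such a swap has not been seen here. Methylsulfanyl in place of methoxy is expected to change potency little; the step is estimated as a 1.6-fold higher number from compound 1 to compound 3 (0.21 log units; within the scatter), a shift toward slightly weaker inhibition that may not exceed the usual scatter. Compound 3 is expected to give 450 nM, within a range from 130 nM to 1600 nM.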

Compound 3, half-maximal inhibitory concentration: 150 nM
Estimate against measurement, compound 3: 3.0-fold (0.48 log units) above; the measured number falls inside the stated range.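

Among these compounds, this is the first step in the set that changes one place only, so it gives the first direct view of how much this position responds to a swap. In this assay, exchanging methoxy for methylsulfanyl on the aromatic carbon para to a large group gives a 1.9-fold lower number from compound 1 to compound 3 (0.27 log units; within the scatter), so the two compounds cannot be told apart and this position accepts sulfur in place of oxygen with no change beyond the scatter. Nothing in the data shown explains why the swap leaves the result so little changed.

On these data alone, whether this position would accept a quite different group, such as an amine, a carboxylic acid or a longer chain, stays open. One swap also cannot show whether the same holds on other cell lines.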